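Furan replaces chlorophenyl on the ketone of the hydroxamate series

A few compounds are considered here, and "the series" means these few. Any claim that something is new, unique, unknown or untested is made for them only; others in the source may bear on it.

Compound 1 `Cn1cc(/C=C/C(=O)c2cccc(Cl)c2)cc1/C=C/C(=O)NO` gives 31400 nM in an assay on isolated protein for inhibition of histone deacetylase HD1B (Zea mays) (on this read-out lower numbers stand for stronger inhibition and higher numbers for weaker inhibition), the highest number of the three measured. Compound 2 `Cn1cc(/C=C/C(=O)c2ccccc2F)cc1/C=C/C(=O)NO` gives 3400 nM and compound 3 `Cn1cc(/C=C/C(=O)c2ccc(F)cc2)cc1/C=C/C(=O)NO` gives 24900 nM. Compound 4 `Cn1cc(/C=C/C(=O)c2ccco2)cc1/C=C/C(=O)NO` differs from compound 1 by furan-2-yl in place of 3-chlorophenyl on a carbonyl carbon. For the measured compounds named here, no measured step exchanges a six-membered ring for a five-membered one, so the bearing steps are only the aryl swaps: a 9.2-fold lower number from compound 1 to compound 2 (0.97 log units; beyond the scatter) and a 1.3-fold lower number from compound 1 to compound 3 (0.10 log units; within the scatter). Exchanges at this carbonyl carbon have thus ranged from no change to a modest drop in number, giving a wide expected band. For compound 4 a modest downward step is expected, a 2.1-fold lower number from compound 1 to compound 4 (0.32 log units; beyond the scatter), with the estimate for compound 4 placed at 15000 nM and expected to fall between 4000 nM and 50000 nM.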

Compound 4, half-maximal inhibitory concentration: 19700 nM
Estimate against measurement, compound 4: 1.3-fold (0.12 log units) below; the range from low to high includes it.
By their numbers in this assay, from the lowest: compound 2; then compounds 4, 3 and 1 (each within the scatter of the next).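

Exchanging a six-membered carbon ring for furan-2-yl on the carbonyl carbon does not separate the numbers in this assay: a 1.6-fold lower number from compound 1 to compound 4 (0.20 log units; within the scatter) and a 1.3-fold lower number from compound 3 to compound 4 (0.10 log units; within the scatter) both stay within the scatter. For the compounds shown here, compound 2 remains apart from the furan, with a 5.8-fold higher number from compound 2 to compound 4 (0.76 log units; beyond the scatter) beyond the scatter, so 2-fluorophenyl is still the only group here that stands out from the others. No evidence available bears on the reason for these differences. Open, going by these compounds, is how an amine, a carboxylic acid or a longer chain on this carbonyl carbon would read in this assay. Also open, on these data alone, is whether any other group matches 2-fluorophenyl.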